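Replacing a Chlorophenyl Ring with a Thiophene Ring

The source may report more compounds than this note shows. Statements on the series, on what has been measured and on what is new or still open speak of the compounds shown alone.

For the measured compounds named here, compound 1 `O=C(CSc1nnc(-c2ccncc2)o1)N/N=C/c1ccc(Cl)cc1` gives 15700 nM in a functional assay on HepG2 cells (Homo sapiens) for cytotoxicity, read by MTT assay, with a stated time of 48 h (on this read-out higher numbers stand for weaker inhibition and lower numbers for stronger inhibition), the higher of the two numbers measured so far. Compound 2 `O=C(CSc1nnc(-c2ccncc2)o1)N/N=C/c1cc(Cl)ccc1O` gives 3970 nM in this assay; that step, a 4.0-fold lower number from compound 1 to compound 2 (0.60 log units; beyond the scatter), came from putting 5-chloro-2-hydroxyphenyl in place of 4-chlorophenyl, a different kind of change, so it offers little guidance here. Compound 3 `O=C(CSc1nnc(-c2ccncc2)o1)N/N=C/c1cccs1` differs from compound 1 by thiophen-2-yl in place of 4-chlorophenyl on a carbon with a double bond to nitrogen. Going by the values given here, with no measured step of this kind to lean on, the change is expected to stay within the scatter, a 1.0-fold lower number from compound 1 to compound 3 (0.02 log units; within the scatter). Compound 3 is therefore estimated at 15000 nM, between 5000 nM and 45000 nM.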

Compound 3, half-maximal inhibitory concentration: 14900 nM
Estimate against measurement, compound 3: 1.0-fold (0.00 log units) above, within the range that was stated.
By their numbers in this assay, from the lowest: compound 2; then compounds 3 and 1 (each within the scatter of the next).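

In this assay, thiophen-2-yl and 4-chlorophenyl cannot be told apart on this carbon, with a 1.1-fold lower number from compound 1 to compound 3 (0.02 log units; within the scatter), so a smaller ring holding sulfur and no chlorine serves as well here as the chlorinated one. Against that level, 5-chloro-2-hydroxyphenyl stands apart, with a 3.8-fold higher number from compound 2 to compound 3 (0.57 log units; beyond the scatter), and it alone among the three groups gives a clearly lower number. No measurement at hand accounts for either step.

Going by these compounds, whether the lower number of compound 2 depends on its chlorine, its hydroxyl or both stays open. So does the result of a thiophen-2-yl ring carrying a hydroxyl, an amine or a carboxylic acid.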